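A few compounds are considered here, and "the series" means these few. Any claim that something is new, unique, unknown or untested is made for them only; others in the source may bear on it.

- compound 1 `O=C(/C(=C\c1ccc(O)c([N+](=O)[O-])c1)SCc1ccc(Br)cc1)c1ccc(Cl)cc1Cl` gives 10000 nM
- compound 2 `COc1ccc(C(=O)/C(=C\c2ccc(O)c([N+](=O)[O-])c2)SCc2ccc(Br)cc2)cc1` gives 10000 nM
- compound 3 `N#Cc1ccc(C(=O)/C(=C\c2ccc(O)c([N+](=O)[O-])c2)SCc2ccc(Br)cc2)cc1` gives 10000 nM

All three values come from a functional assay on DU-145 cells (Homo sapiens) for inhibition, read by trypan blue exclusion, with a stated time of 96 h; on this read-out higher numbers stand for weaker inhibition of growth and lower numbers for stronger inhibition of growth. Compound 3 stands level with compound 1 and compound 2 on these numbers, so nothing in the set yet separates one member from another.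

The next member is compound 4 `O=C(/C(=C\c1ccc(O)c([N+](=O)[O-])c1)SCc1ccc(Br)cc1)C1CCNC1`, which carries pyrrolidin-3-yl in place of 4-cyanophenyl on a carbonyl carbon.

Among the compounds with values here, three measured steps bear on this change, all of them at the same carbonyl carbon: no change at the digits printed from compound 1 to compound 2 (within the scatter), no change at the digits printed from compound 1 to compound 3 (within the scatter) and no change at the digits printed from compound 2 to compound 3 (within the scatter). Each lies within the scatter, whether the phenyl group carries methoxy, cyano or two chloro substituents. These steps only exchange one substituted phenyl group for another, however. Within the data shown here, the data hold no example of a non-aromatic ring at this place, so they offer only partial guidance for compound 4.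

No step beyond the scatter is therefore expected in this assay, and this expectation is held with modest confidence. The expected step is a 1.3-fold lower number from compound 3 to compound 4 (0.10 log units; within the scatter). For compound 4 the estimated value is 8000 nM, with an expected range from 2500 nM to 15000 nM.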

Compound 4, concentration for 50% growth inhibition: > 100000 nM
Compound 4: a limit, no number; the forecaster's own chance of this, stated with the estimate: 35%; at least 12-fold (1.09 log units) between middle value and limit.
By their numbers in this assay, from the lowest: compounds 1, 2 and 3 (each within the scatter of the next). At a limit, above all of these: compound 4.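

In this assay, within the data shown here, compound 4 gives > 100000 nM as a limit and not a number, and it is the only member at such a limit: the limit of > 100000 nM in this assay, at which 1 of the 4 values shown sits.

Among these compounds, the carbonyl carbon, silent while one substituted phenyl group replaced another, now separates members of the set: an at least 10-fold higher number from compound 3 to compound 4 (1.00 log units; beyond the scatter) and an at least 10-fold higher number from compound 2 to compound 4 (1.00 log units; beyond the scatter) and an at least 10-fold higher number from compound 1 to compound 4 (1.00 log units; beyond the scatter) are the first steps beyond the scatter. The growth inhibition seen with the 2,4-dichlorophenyl, 4-methoxyphenyl and 4-cyanophenyl groups therefore does not carry over to pyrrolidin-3-yl, so this place does not accept every ring.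

The change alters the ring size, the loss of aromatic character and the ring nitrogen with its hydrogen-bond donor all at once, and the compounds shown cannot assign the loss to any one of these. Cyclopentyl would keep a non-aromatic ring without the nitrogen and a pyridyl ring would keep a nitrogen in an aromatic ring, so these two groups, or an acetyl group on the pyrrolidine nitrogen, would help to separate these features.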